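A single stability value and one group swap

This account rests on a few compounds, and the source may have more. Where it says the series, first, only, none or still open, it means among the compounds named here.

Compound 1 `O=C(CCS(=O)(=O)c1cccc2ncsc12)N1CCN(c2ccnc(C(F)(F)F)c2)CC1`: "not determined" (no result reported)
Compound 2 `N#Cc1cc(N2CCN(C(=O)CCS(=O)(=O)c3cccc4ncsc34)CC2)ccn1`: "not determined" (no result reported)
Compound 3 `O=C(CCS(=O)(=O)c1cccc2ncsc12)N1CCN(c2ccncc2F)CC1`: 29%

Among the measured compounds shown here, in an ADME assay on microsomes from liver (Rattus norvegicus) for metabolic stability, read by LC-MS, with a stated time of 15 min, tested at 1 uM (on this read-out lower numbers stand for a less stable compound and higher numbers for a more stable compound), compound 3 gives 29% and this is the only number available. Compound 1 and compound 2 have no result. The next structure, compound 4 `N#Cc1ccc(N2CCN(C(=O)CCS(=O)(=O)c3cccc4ncsc34)CC2)nc1`, has 5-cyanopyridin-2-yl in place of 3-fluoropyridin-4-yl on an amine nitrogen in a ring while the rest of the molecule stays the same. For the measured compounds named here, with only compound 3 at 29% to go on, no measured pair shows what such a swap does, so no step beyond the usual scatter is expected in either direction. The expected step is a number 1 percentage points higher from compound 3 to compound 4 (within the scatter) and stays inside that scatter. For compound 4 the estimated value is 30% with 10% to 55% as the expected range.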

Compound 4, percent of the compound remaining: 59%
For compound 4 the middle estimate is 29 percentage points below the measured one; measured number above the stated range.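

In this assay, among the compounds shown here, putting 5-cyanopyridin-2-yl in place of 3-fluoropyridin-4-yl on the ring amine nitrogen gives a number 30 percentage points higher from compound 3 to compound 4 (beyond the scatter), the first sign that the group at this position matters for this read-out. No measurement shown here explains the step. The swap replaces the whole aromatic ring together with its group, so the nitrile and the ring cannot be told apart as the source of the step. As far as these compounds go, whether a methoxy group in place of the nitrile on the same ring would keep the higher value stays open.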